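A few compounds are considered here, and "the series" means these few. Any claim that something is new, unique, unknown or untested is made for them only; others in the source may bear on it.

Measured compounds:
compound 1, `O=C(Nc1ccc(Cc2ccccc2)cc1)Nc1nn(C(=O)Nc2ccc(Cc3ccccc3)cc2)c2ccccc12`, > 100000 nM in a functional assay on SK-MEL-28 cells (Homo sapiens) for inhibition, read by sulforhodamine B assay, with a stated time of 48 h; on this read-out higher numbers stand for weaker inhibition of growth and lower numbers for stronger inhibition of growth
compound 2, `Nc1nn(C(=O)Nc2ccc(Cc3ccccc3)cc2)c2ccccc12`, 11500 nM in this assay

In this assay compound 1 gives only a limit, > 100000 nM, not a number. Among the compounds with values here, compound 2 is therefore the one compound with a measured value in this assay, where it gives 11500 nM. The remaining entry belongs to compound 1 and is a limit, the point described by the limit of > 100000 nM in this assay, at which 1 of the 2 values shown sits.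

Compound 3, `CCCCOc1ccc(NC(=O)n2nc(N)c3ccccc32)cc1`, has not been measured. It differs from compound 2 in one place: butoxy in place of benzyl on an aromatic carbon. Within the data shown here, no measured pair shows what this exchange does, so the expectation rests on compound 2 alone. The shared core and the urea linkage are kept, and compound 3 is expected to stay close to compound 2, the step of a 1.3-fold higher number from compound 2 to compound 3 (0.12 log units; within the scatter) being estimated as none beyond the scatter or a modest weakening. Compound 3 is thus expected to give about 15000 nM in this assay, within a range of 5000 nM to 50000 nM.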

Compound 3, concentration for 50% growth inhibition: 32600 nM
Compound 3: the middle estimate sits 2.2-fold (0.34 log units) below what was measured; low and high end bracket the measured number.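

In this assay, exchanging benzyl for butoxy on this aromatic carbon, para to a large group, gives a 2.8-fold higher number from compound 2 to compound 3 (0.45 log units; beyond the scatter), so the group held at this position does affect growth inhibition. The change is modest: with the carbon-only ring gone and an oxygen brought in, compound 3 still gives a measured value of 32600 nM, so this position can carry an open chain in place of a ring. Nothing measured here accounts for the step, and this single exchange cannot separate the loss of the ring from the arrival of the oxygen.

The compounds shown leave open whether methoxy, a longer alkoxy chain or a plain butyl chain at this place would shift the number further. From the compounds shown here alone, it also remains open how an amine or a carboxylic acid on this carbon would behave.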